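Indazole for Hydroxyethylphenyl: Expected Return Toward Higher Lipophilicity

The compounds below may be only part of what the source reports. "The series", "measured", "known", "first", "only" and "open" are said of these compounds alone.

Measured compounds:
compound 1, `CNC(=O)c1cc(C(=O)NC2CC2)cn(Cc2cccc3cc[nH]c23)c1=O`, 3.7
compound 2, `CNC(=O)c1cc(C(=O)NC2CC2)cn(Cc2cccc([C@@H](C)O)c2)c1=O`, 2.2

Of the compounds shown here, two have been measured in a physicochemical assay for lipophilicity, at pH 7.4 (a higher number here means a more lipophilic compound, a lower number a more polar compound), which reports a distribution coefficient in log units. Compound 2 stands lowest of the two numbers; its nearest neighbour is compound 1, and the step of a number 1.50 log units lower from compound 1 to compound 2 (beyond the scatter) is well beyond the scatter. Compound 3, `CNC(=O)c1cc(C(=O)NC2CC2)cn(Cc2cccc3cn[nH]c23)c1=O`, has not yet been measured. It differs from compound 2 in one place: 1H-indazol-7-yl in place of 3-(1-hydroxyethyl)phenyl on a saturated chain carbon bound to an aromatic nitrogen.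

Among the compounds with values here, the only measured step that bears on this is a number 1.50 log units lower from compound 1 to compound 2 (beyond the scatter), a large drop when the 1H-indol-7-yl group gave way to 3-(1-hydroxyethyl)phenyl. The change from compound 2 to compound 3 runs the other way, but the entering 1H-indazol-7-yl, with its five-membered aromatic ring holding 2 hetero atoms, is not the group that compound 1 carries, so the full reversal is not expected. Compound 3 is therefore expected to rise by a number 0.80 log units higher from compound 2 to compound 3 (beyond the scatter), landing between compound 2 and compound 1. The estimate for compound 3 is 3, with a range from 2.5 to 3.5.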

Compound 3, distribution coefficient: 2.2
For compound 3 the middle estimate is 0.80 log units above the measured one; the whole stated range lies above it.
By their numbers in this assay, from the lowest: compounds 2 and 3 (each within the scatter of the next); then compound 1.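

In this assay, placing 1H-indazol-7-yl on a saturated chain carbon bound to an aromatic nitrogen gives no change at the digits printed from compound 2 to compound 3 (within the scatter), although this group carries a five-membered aromatic ring with 2 hetero atoms that 3-(1-hydroxyethyl)phenyl lacks. The more telling comparison is a number 1.50 log units lower from compound 1 to compound 3 (beyond the scatter), which shows that a large step at this place can arise between 1H-indol-7-yl and 1H-indazol-7-yl, so having two aromatic rings in the group does not by itself bring the number up to that of compound 1. Nothing available accounts for this outcome. From the compounds shown here alone, it remains open how this assay would read with an amine or a carboxylic acid at this place. Also open, going by these compounds, is whether a longer chain between the aromatic nitrogen and 1H-indol-7-yl would keep the number of compound 1.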